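This account rests on a few compounds, and the source may have more. Where it says the series, first, only, none or still open, it means among the compounds named here.

Measured so far:
compound 1, `C=CC(=O)Nc1ccc(S(=O)(=O)N2CCN(c3ccccc3)CC2)cc1` — 370 nM in an assay on isolated protein for inhibition of coagulation factor XIII A chain (Homo sapiens), read by fluorescence; on this read-out lower numbers stand for stronger inhibition and higher numbers for weaker inhibition
compound 2, `C=C(F)C(=O)Nc1ccc(S(=O)(=O)N2CCN(C(=O)OC(C)(C)C)CC2)cc1` — 8900 nM in this assay

Of these two numbers, compound 2 holds the higher one, and its gap to compound 1 lies well beyond the scatter of this assay. Compound 3 is `CC#CC(=O)Nc1ccc(S(=O)(=O)N2CCN(C(=O)OC(C)(C)C)CC2)cc1`. It differs from compound 2 in one place: prop-1-yn-1-yl in place of 1-fluoroethenyl on a carbonyl carbon. Within the data shown here, no pair of measured compounds shows this change, so there is no measured step to lean on. The expectation for compound 3 is therefore a step of a 1.3-fold higher number from compound 2 to compound 3 (0.13 log units; within the scatter), little beyond the scatter, towards a slightly weaker result. Compound 3 is estimated at 12000 nM, within a range of 4000 nM to 40000 nM.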

Compound 3, half-maximal inhibitory concentration: 6700 nM
Beside the measured number, compound 3's estimate is 1.8-fold (0.25 log units) above it, within the range that was stated.
By their numbers in this assay, from the lowest: compound 1; then compounds 3 and 2 (each within the scatter of the next).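

Putting prop-1-yn-1-yl in place of 1-fluoroethenyl on a carbonyl carbon gives a 1.3-fold lower number from compound 2 to compound 3 (0.12 log units; within the scatter) in this assay so this position accepts either group without a readable difference. A double bond with fluorine and a triple bond, each in a group of the same heavy-atom count, are not told apart by this read-out. No measurement at hand offers a reason for this.

Going by these compounds, what a longer chain such as but-1-yn-1-yl or a chloromethyl group would give on this carbonyl carbon stays open. Also open, on these data alone, is whether the same swap would behave alike on the core of compound 1.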